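The source may report more compounds than this note shows. Statements on the series, on what has been measured and on what is new or still open speak of the compounds shown alone.

Compound 1 `COc1cc(O)c(C(=O)/C=C/c2cc(Cl)cc(Cl)c2)c(OC)c1`: 1900 nM
Compound 2 `COc1cc(OC)c(C(=O)/C=C/c2ccc(F)cc2)c(OCC=C(C)C)c1`: 3200 nM
Compound 3 `COc1cccc(/C=C/C(=O)c2c(OC)cc(OC)cc2OCC=C(C)C)c1`: 7700 nM

In a functional assay on HCT-116 cells (Homo sapiens) for antiproliferative activity, read by sulforhodamine B assay, with a stated time of 48 h (a higher number here means a weaker inhibitor, a lower number a stronger inhibitor), compound 3 has the highest number of the three at 7700 nM, which makes it the weakest inhibitor measured so far. The next compound, compound 4 `COc1cc(OC)c(C(=O)/C=C/c2cc(Cl)cc(Cl)c2)c(OCC=C(C)C)c1`, keeps the rest of compound 3 and changes one group: 3,5-dichlorophenyl stands in place of 3-methoxyphenyl on a double-bonded chain carbon bound to a double-bonded chain carbon (3,5-dichlorophenyl in place of 3-methoxyphenyl on a double-bonded chain carbon bound to a double-bonded chain carbon).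

Among the measured compounds shown here, only one measured step concerns this same place: a 2.4-fold higher number from compound 2 to compound 3 (0.38 log units; beyond the scatter). It shows that exchanging the group here can move the number, though only modestly. For the measured compounds named here, compound 1 already carries 3,5-dichlorophenyl and gives 1900 nM, a lower number than compound 3 shows, but its core differs, so no measured step isolates this group. These two observations point, weakly, toward a modest step to a lower number in this assay, similar in size to the one measured.

The expected change is a 2.6-fold lower number from compound 3 to compound 4 (0.41 log units; beyond the scatter), although it rests on very few data. For compound 4 the estimated value is 3000 nM, with an expected range from 1000 nM to 8000 nM.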

Compound 4, half-maximal inhibitory concentration: 24500 nM
The estimate for compound 4 lay 8.2-fold (0.91 log units) below the measured number; the measured number lies above the stated range.
By their numbers in this assay, from the lowest: compounds 1 and 2 (each within the scatter of the next); then compound 3; then compound 4.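

Within this assay the exchange of 3-methoxyphenyl for 3,5-dichlorophenyl gives a 3.2-fold higher number from compound 3 to compound 4 (0.50 log units; beyond the scatter) and so moves the number upward on this core, making the group the poorest of the three tried at this place. Among the compounds shown here, the exchange of 4-fluorophenyl for the same group gives a 7.7-fold higher number from compound 2 to compound 4 (0.88 log units; beyond the scatter) and this wider gap shows that the choice of ring at this place matters more than the one earlier step could show. Placing 3-methylbut-2-en-1-yl instead of hydrogen on an oxygen on an aromatic ring gives a 13-fold higher number from compound 1 to compound 4 (1.11 log units; beyond the scatter) and this large step shows that the low number of compound 1 does not carry over to a compound with this chain, even though both carry 3,5-dichlorophenyl.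

Still open, from the compounds shown here alone, is whether a ring bearing an amine or a carboxylic acid at this place would bring the number down, and whether a chain shorter than 3-methylbut-2-en-1-yl on that oxygen would recover part of the loss. Nothing available explains why the number rose in these steps.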